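A few compounds are considered here, and "the series" means these few. Any claim that something is new, unique, unknown or untested is made for them only; others in the source may bear on it.

Measured so far in a functional assay on A375M cells (Homo sapiens) for cytotoxicity, read by MTT assay, with a stated time of 4 days; a lower number here means a stronger inhibitor, a higher number a weaker inhibitor
Compound 1 (`C=C1C(=O)OC(CCc2ccccc2)C1CCCC`) gives 5000 nM in this series
Compound 2 (`C=C1C(=O)OC(CCCC)C1CCc1ccccc1`) gives 5500 nM in this series
Compound 3 (`C=C1C(=O)OC(c2ccccc2)C1CCc1ccccc1`) gives 2800 nM in this series

Compound 2 at 5500 nM lies within the scatter of both other measured compounds. Going to compound 4 (`C=C1C(=O)OC(CCc2ccccc2)C1CCc1ccccc1`), the change is phenyl in place of ethyl on a saturated chain carbon, two bonds along the chain from a saturated ring carbon. Among the measured compounds shown here, the one measured step that bears on it (a 2.0-fold lower number from compound 2 to compound 3 (0.29 log units; within the scatter)) also brings in phenyl, there replacing butyl, and stays within the scatter. In this assay no step beyond the scatter is therefore expected, at most a small one toward a lower number (a 1.6-fold lower number from compound 2 to compound 4 (0.20 log units; within the scatter)). For compound 4 the estimate is 3500 nM with an expected range from 1600 nM to 7500 nM in this series.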

Compound 4, half-maximal inhibitory concentration: 2700 nM
Compound 4: middle estimate off by 1.3-fold (0.11 log units), on the high side; low and high end bracket the measured number.
By their numbers in this assay, from the lowest: compounds 4, 3, 1 and 2 (each within the scatter of the next, the first and the last beyond it).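

In this assay phenyl in place of ethyl on a saturated chain carbon, two bonds along the chain from a saturated ring carbon, gives a 2.0-fold lower number from compound 2 to compound 4 (0.31 log units; beyond the scatter) and also a 1.9-fold lower number from compound 1 to compound 4 (0.27 log units; within the scatter) so the same change now has two readings on the shared core. Neither goes toward a higher number, and only the first lies beyond the scatter, modestly. A phenyl at the end of both chains is therefore accepted, without a large step.

From the compounds shown here alone, whether a longer chain ending in phenyl, or an amine or carboxylic acid on that phenyl, would move the number further remains open. No supporting data account for these steps.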